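Aryl swap from compound 3 to compound 4

This account rests on a few compounds, and the source may have more. Where it says the series, first, only, none or still open, it means among the compounds named here.

Among the measured compounds shown here, in a functional assay with Homo sapiens as the target (on this read-out lower numbers stand for stronger inhibition and higher numbers for weaker inhibition), three compounds sharing one core have numbers so far. Compound 1 (`CC(C)[C@H](NC(=O)COc1cccc2ccccc12)C(=O)N[C@@H](CC(=O)O)C(=O)COc1ccccc1C(F)(F)F`) gives 17300 nM, compound 2 (`CC(C)[C@H](NC(=O)COc1cccc2ccccc12)C(=O)N[C@@H](CC(=O)O)C(=O)COc1cccc(C(F)(F)F)c1`) gives 16600 nM and compound 3 (`CC(C)[C@H](NC(=O)COc1cccc2ccccc12)C(=O)N[C@@H](CC(=O)O)C(=O)COc1cc(F)cc(F)c1F`) gives 11200 nM. Compound 3 therefore stands level with the other two, with a 1.5-fold lower number from compound 1 to compound 3 (0.19 log units; within the scatter) and a 1.5-fold lower number from compound 2 to compound 3 (0.17 log units; within the scatter).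

Compound 4 (`CC(C)[C@H](NC(=O)COc1cccc2ccccc12)C(=O)N[C@@H](CC(=O)O)C(=O)COc1c(F)c(F)c(F)c(F)c1F`) carries one change: 2,3,4,5,6-pentafluorophenyl in place of 2,3,5-trifluorophenyl on an oxygen on a saturated carbon. In words, 2,3,4,5,6-pentafluorophenyl replaces 2,3,5-trifluorophenyl on an oxygen on a saturated carbon.

For the measured compounds named here, no measured step adds fluorine to a fluorinated ring directly, so the evidence is indirect. The three measured steps all exchange the group at this same place, and together with a 1.0-fold lower number from compound 1 to compound 2 (0.02 log units; within the scatter), the two steps to compound 3 stay inside the scatter. On that basis, no step beyond the scatter is expected in this assay, and no direction is favoured. The expected step is a 1.1-fold higher number from compound 3 to compound 4 (0.03 log units; within the scatter). Compound 4 is estimated at 12000 nM, with an expected range of 5500 nM to 26000 nM.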

Compound 4, half-maximal inhibitory concentration: 8890 nM
For compound 4 the middle estimate is 1.3-fold (0.13 log units) above the measured one, within the range that was stated.
By their numbers in this assay, from the lowest: compounds 4, 3, 2 and 1 (each within the scatter of the next).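

In this assay, taking the ring from three fluorines to five at this place, 2,3,4,5,6-pentafluorophenyl for 2,3,5-trifluorophenyl, leaves the number within the scatter (a 1.3-fold lower number from compound 3 to compound 4 (0.10 log units; within the scatter)). The comparisons with the two trifluoromethyl-bearing rings also stay within it (a 1.9-fold lower number from compound 2 to compound 4 (0.27 log units; within the scatter)) and (a 1.9-fold lower number from compound 1 to compound 4 (0.29 log units; within the scatter)), so all four aryl groups on this oxygen remain level with one another in this read-out. Nothing on hand accounts for this flat response.

Going by these compounds, all four groups are fluorine-bearing phenyl rings, so it remains open whether the level holds for an unsubstituted phenyl or for a phenyl carrying an amine or a carboxylic acid. Also open, on these data alone, is whether a saturated chain in place of the aryl group would give a step beyond the scatter.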